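A change on the sulfonyl sulfur of compound 1

The source may report more compounds than this note shows. Statements on the series, on what has been measured and on what is new or still open speak of the compounds shown alone.

Measured in an ADME assay on CHO cells (Cricetulus griseus) for cytotoxicity, read by MTT assay; a lower number here means a stronger inhibitor, a higher number a weaker inhibitor:
compound 1 `O=S(=O)(NCC1COC1)c1cccc(-c2ccc3nccc(-c4ccncc4)c3n2)c1`: 16000 nM
compound 2 `CS(=O)(=O)c1cccc(Nc2ccc3nccc(-c4ccncc4)c3n2)c1`: > 50000 nM
compound 3 `O=S(=O)(NCCN1CCCC1)c1cccc(-c2ccc3nccc(-c4ccnc(C(F)(F)F)c4)c3n2)c1`: 13000 nM

Only two of these results are exact numbers. Compound 1 at 16000 nM and compound 3 at 13000 nM lie within the scatter of each other, so neither stands apart from the other. Compound 2 gives only a limit, > 50000 nM.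

The next compound is compound 4 `O=S(=O)(c1cccc(-c2ccc3nccc(-c4ccncc4)c3n2)c1)N1CCC(O)CC1`, which has 4-hydroxypiperidin-1-yl in place of ((oxetan-3-yl)methyl)amino on a sulfonyl sulfur. Among the compounds with values here, no measured pair in this set differs in one place only, so no measured step can guide the expectation in this assay. The estimate therefore starts from compound 1 at 16000 nM, and no change beyond the scatter is expected. The expected step of a 1.3-fold higher number from compound 1 to compound 4 (0.10 log units; within the scatter) is accordingly small. Compound 4 is estimated at 20000 nM, with an expected range of 8000 nM to 50000 nM.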

Compound 4, half-maximal inhibitory concentration: 8000 nM
Beside the measured number, compound 4's estimate is 2.5-fold (0.40 log units) above it; the range from low to high includes it.
By their numbers in this assay, from the lowest: compounds 4, 3 and 1 (each within the scatter of the next). At a limit, above all of these: compound 2.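

Within the data shown here, this is the first pair in this assay that differs in one place only, and it gives a direct reading of the group on the sulfonyl sulfur: a 2.0-fold lower number from compound 1 to compound 4 (0.30 log units; within the scatter). The step lies within the scatter, so 4-hydroxypiperidin-1-yl and ((oxetan-3-yl)methyl)amino cannot be told apart here, even though one group brings a six-membered non-aromatic ring and the other a four-membered one. Nothing shown here gives a cause for this result.

This reading rests on a single pair, so it cannot be extended to other groups at this place. As far as these compounds go, it remains open whether a carboxylic acid on a longer chain, or a plain dimethylamino group, on the sulfonyl sulfur would stay within the scatter of compound 1.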